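The source may report more compounds than this note shows. Statements on the series, on what has been measured and on what is new or still open speak of the compounds shown alone.

Two measured compounds share a core and differ only in the substituent on the aryl thiourea. Compound 1 `NC(=O)c1c(NC(=O)c2ccccc2I)sc2c1CCN(C(=S)Nc1ccccc1Cl)C2` gives 17500 nM in a functional assay on MKN-74 cells (Homo sapiens) for antiproliferative activity, with a stated time of 24 h; a lower number here means a stronger inhibitor, a higher number a weaker inhibitor. Among the compounds with values here, compound 2 `COc1ccccc1NC(=S)N1CCc2c(sc(NC(=O)c3ccccc3I)c2C(N)=O)C1` gives 41800 nM in this assay, which is the higher of the two numbers; the only step recorded is a 2.4-fold higher number from compound 1 to compound 2 (0.38 log units; beyond the scatter), a methoxy in place of chloro on an aromatic carbon.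

Compound 3 `COc1ccccc1NC(=S)N1CCc2c(sc(NC(=O)c3ccccc3C(F)(F)F)c2C(N)=O)C1` changes compound 2 at a different place: trifluoromethyl in place of iodo on an aromatic carbon. Within the data shown here, none of the measured steps touches this position or this pair of groups, so the step from compound 1 to compound 2 says nothing about what an exchange of iodo for trifluoromethyl on the benzoyl ring will do. Among the measured compounds shown here, with no comparable step to lean on, compound 3 is expected to land within the scatter of compound 2, and the step of a 1.0-fold lower number from compound 2 to compound 3 (0.02 log units; within the scatter) is therefore estimated as no change beyond the usual spread, with a correspondingly wide range. Compound 3 is thus estimated at 40000 nM in this assay, between 14000 nM and 110000 nM.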

Compound 3, half-maximal inhibitory concentration: 34500 nM
Compound 3: the middle estimate sits 1.2-fold (0.06 log units) above what was measured, within the range that was stated.
By their numbers in this assay, from the lowest: compounds 1, 3 and 2 (each within the scatter of the next, the first and the last beyond it).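

In this assay, the exchange of 2-iodophenyl for 2-(trifluoromethyl)phenyl gives a 1.2-fold lower number from compound 2 to compound 3 (0.08 log units; within the scatter), so compound 2 and compound 3 cannot be told apart, even though four heavy atoms enter where one left. Within the data shown here, this is the first reading at this position, since the earlier step from compound 1 to compound 2 concerned only the substituent on the aryl thiourea, and it shows that at least this one exchange on an aromatic carbon, ortho to a large group, leaves the number within the scatter. No measurement offered here bears on why the two groups read alike.

As far as these compounds go, both groups counted at this position carry no hydrogen-bond donors, no hydrogen-bond acceptors and no net charge, so it remains open whether an amine or a carboxylic acid in their place would read the same. Among these compounds, it is also open whether the exchange would hold with chloro rather than methoxy on the aryl thiourea, since this position is seen only with the methoxy partner.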